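A few compounds are considered here, and "the series" means these few. Any claim that something is new, unique, unknown or untested is made for them only; others in the source may bear on it.

Measured so far:
Compound 1 `O=[N+]([O-])c1ccc(-c2nc3ccccc3[nH]2)cc1` gives 3.07 in a physicochemical assay for lipophilicity, measured as octanol-water partition; a lower number here means a more polar compound, a higher number a more lipophilic compound.
Compound 2 `O=C(c1cccnc1)n1c(-c2ccc(Cl)cc2)nc2ccccc21` gives 4.7 in this assay.
Compound 3 `O=C(c1cccnc1)n1c(-c2cccc(Cl)c2)nc2ccccc21` gives 4.7 in this assay.

Compound 2 stands level with compound 3, the two together being the highest of the three numbers, while compound 1 lies well below both, beyond the scatter. Compound 4 `O=C(c1cccnc1)n1c(-c2ccc([N+](=O)[O-])cc2)nc2ccccc21` has not yet been measured; it differs from compound 2 by nitro in place of chloro on an aromatic carbon. Going by the values given here, the only measured step, no change at the digits printed from compound 2 to compound 3 (within the scatter), moves the chloro to another position and says nothing about exchanging it for a nitro. Compound 1 carries a nitro but differs from compound 2 in more than one place, so its lower value is only a hint. On that hint, a downward step of a number 1.00 log units lower from compound 2 to compound 4 (beyond the scatter) is expected, giving an estimated 3.7 for compound 4, likely between 3.2 and 4.3.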

Compound 4, partition coefficient: 4.13
Compound 4: middle estimate off by 0.43 log units, on the low side, and the stated range covers the measured number.
By their numbers in this assay, from the lowest: compound 1; then compound 4; then compounds 2 and 3 (each within the scatter of the next).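

In this assay nitro in place of chloro on the aromatic carbon para to a large group gives a number 0.57 log units lower from compound 2 to compound 4 (beyond the scatter) and so, unlike the earlier shift of the chloro, this exchange at this place changes the number beyond the scatter. Placing (pyridin-3-yl)carbonyl in place of hydrogen on the aromatic nitrogen of the core gives a number 1.06 log units higher from compound 1 to compound 4 (beyond the scatter) as a separate single change, and it is the larger step of the two. Whether an amine or a carboxylic acid at the same place would land nearer compound 2 or compound 4 stays open, and the data offer no explanation for either step.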